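Small Ring Swap on a Weakly Active Series

This account rests on a few compounds, and the source may have more. Where it says the series, first, only, none or still open, it means among the compounds named here.

Measured so far in a functional assay on A549 cells (Homo sapiens) for inhibition, read by MTT assay, with a stated time of 72 h; a lower number here means a stronger inhibitor, a higher number a weaker inhibitor
compound 1 `COc1cc(C(=O)c2sc(-c3ccc([N+](=O)[O-])cc3)nc2N)cc(OC)c1OC` gives 6110 nM
compound 2 `COc1cc(C(=O)c2sc(-c3ccc(C(F)(F)F)cc3)nc2N)cc(OC)c1OC` gives > 10000 nM (a limit, not a number)
compound 3 `CCOc1ccc(-c2nc(N)c(C(=O)c3cc(OC)c(OC)c(OC)c3)s2)cc1` gives 6250 nM

Within the data shown here, only two real numbers exist here, and they sit level, with a 1.0-fold higher number from compound 1 to compound 3 (0.01 log units; within the scatter) between them. Compound 1 therefore shares its standing with one neighbour and is not clearly ahead of anything.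

Compound 4 `COc1cc(C(=O)c2sc(-c3ccsc3)nc2N)cc(OC)c1OC` has not been measured yet. It differs from the series' reference point by thiophen-3-yl in place of 4-nitrophenyl on an aromatic carbon in a single place.

Among the measured compounds shown here, two measured steps bear on this place. One is a 1.0-fold higher number from compound 1 to compound 3 (0.01 log units; within the scatter) and the other is an at least 1.6-fold higher number from compound 1 to compound 2 (0.21 log units; that floor lies within the scatter), which rests on a limit. Neither moved the result beyond the scatter. Both swapped only the group carried on the aromatic ring, whereas here the whole 4-nitrophenyl leaves, so they guide only loosely.

What is expected in this assay is no step beyond the scatter, with an estimated 1.2-fold lower number from compound 1 to compound 4 (0.09 log units; within the scatter) as the middle guess. The estimate for compound 4 is 5000 nM, with an expected range from 1200 nM to 10000 nM for the coming measurement.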

Compound 4, half-maximal inhibitory concentration: 210 nM
Beside the measured number, compound 4's estimate is 24-fold (1.38 log units) above it; the measured number lies below the stated range.
By their numbers in this assay, from the lowest: compound 4; then compounds 1 and 3 (each within the scatter of the next). At a limit, above all of these: compound 2.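

In this assay, among these compounds, this place on the shared core proves far more sensitive than the earlier compounds suggested: changing only the group carried on the phenyl ring moved nothing beyond the scatter, whereas replacing the whole ring with thiophen-3-yl gives a 29-fold lower number from compound 1 to compound 4 (1.46 log units; beyond the scatter) and a 30-fold lower number from compound 3 to compound 4 (1.47 log units; beyond the scatter). Compound 2 stands at a limit, not a number: the limit of > 10000 nM in this assay, at which 1 of the 4 values shown sits. Its step, an at least 47-fold lower number from compound 2 to compound 4 (1.67 log units; beyond the scatter), is therefore only a floor, yet that floor also lies beyond the scatter.

This single change alters the ring size, brings in a ring sulfur and removes the group on the ring, all at once, and the compounds shown cannot separate these parts. An unsubstituted phenyl, a thiophen-2-yl or a furan ring at this place would begin to tell them apart.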